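Chloro for fluoro on the sulfonyl aryl ring

This account rests on a few compounds, and the source may have more. Where it says the series, first, only, none or still open, it means among the compounds named here.

The measured compounds and their half-maximal inhibitory concentrations in a functional assay on QGY-7703 cells (Homo sapiens) for cytotoxicity, read by MTT assay, with a stated time of 24 h; on this read-out lower numbers stand for stronger inhibition and higher numbers for weaker inhibition:
compound 1 `O=C1/C(=C/c2cccnc2)CN(S(=O)(=O)c2ccc(F)cc2)C/C1=C\c1ccccc1F`: 15300 nM
compound 2 `O=C1/C(=C/c2cccnc2)CN(S(=O)(=O)c2ccc(Cl)cc2)C/C1=C\c1ccccc1F`: 12100 nM
compound 3 `O=C1/C(=C/c2ccncc2)CN(S(=O)(=O)c2ccc(F)cc2)C/C1=C\c1ccccc1C(F)(F)F`: 7700 nM

Compound 1 and compound 2 share one core and differ only by chloro in place of fluoro on an aromatic carbon. This change produced a 1.3-fold lower number from compound 1 to compound 2 (0.10 log units; within the scatter), a step too small to read as a real difference. Compound 3 carries a different core; the difference between the two cores is not broken down here. Compound 4 `O=C1/C(=C/c2ccncc2)CN(S(=O)(=O)c2ccc(Cl)cc2)C/C1=C\c1ccccc1C(F)(F)F`, not yet measured, stands to compound 3 exactly as compound 2 stands to compound 1, differing by chloro in place of fluoro on an aromatic carbon, the same change in the same place. Because the earlier step of a 1.3-fold lower number from compound 1 to compound 2 (0.10 log units; within the scatter) was small, a similarly small step is expected in this assay, a 1.2-fold lower number from compound 3 to compound 4 (0.07 log units; within the scatter). Compound 4 is thus expected to give 6500 nM, most likely between 3500 nM and 12000 nM.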

Compound 4, half-maximal inhibitory concentration: 12700 nM
The estimate for compound 4 lay 2.0-fold (0.29 log units) below the measured number, and the stated range ends below it.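

In this assay, the change from 4-fluorophenyl to 4-chlorophenyl gave a 1.6-fold higher number from compound 3 to compound 4 (0.22 log units; within the scatter), so this step, like the earlier one, cannot be read as a real difference. The two steps point in opposite directions on paper, but they do not differ beyond what repeated measurements allow: the same change on two cores in this assay, a 1.3-fold lower number (0.10 log units; within the scatter) from compound 1 to compound 2 and a 1.6-fold higher number (0.22 log units; within the scatter) from compound 3 to compound 4, 2.1-fold (0.32 log units) apart, within the scatter of two such steps. This shows that the change left the number within the scatter on both of these cores, but it does not show that the change is without effect elsewhere, and steps this small fix no direction for it.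

Only fluoro and chloro stand at this place among the compounds shown. From the compounds shown here alone, what a methoxy group, an amine or a carboxylic acid would do there remains open, as does the size of the step on any further core.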